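The source may report more compounds than this note shows. Statements on the series, on what has been measured and on what is new or still open speak of the compounds shown alone.

Measured in a functional assay on HL-60 cells (Homo sapiens) for antiproliferative activity, with a stated time of 72 h; on this read-out lower numbers stand for stronger inhibition and higher numbers for weaker inhibition:
- compound 1 `CCCCC#Cc1cc([C@@H]2O[C@H](CO)[C@@H](O)[C@H]2O)n2ncnc(N)c12`: 400 nM
- compound 2 `Nc1ncnn2c([C@@H]3O[C@H](CO)[C@@H](O)[C@H]3O)cc(-c3ccoc3)c12`: 500 nM

Among the compounds with values here, only two numbers exist so far, and compound 2 at 500 nM lies within the scatter of compound 1 at 400 nM. The next compound, compound 3 `Nc1ncnn2c([C@@H]3O[C@H](CO)[C@@H](O)[C@H]3O)cc(/C=C/c3ccccc3)c12`, keeps the shared core and changes one group: 2-phenylethenyl in place of furan-3-yl on an aromatic carbon. In words, 2-phenylethenyl takes the place of furan-3-yl on an aromatic carbon. Within the data shown here, one measured step bears on this, a 1.3-fold higher number from compound 1 to compound 2 (0.10 log units; within the scatter), where furan-3-yl replaced hex-1-yn-1-yl on that same carbon, and it stayed within the scatter. On that single step, no change beyond the scatter is expected in this assay, perhaps with a slight drift to a higher number. Among the measured compounds shown here, no measured compound carries 2-phenylethenyl, so the range stays wide. The expected step is a 1.4-fold higher number from compound 2 to compound 3 (0.15 log units; within the scatter). For compound 3 the estimated value is 700 nM, with an expected range of 150 nM to 4000 nM.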

Compound 3, half-maximal inhibitory concentration: 2000 nM
Compound 3: the middle estimate sits 2.9-fold (0.46 log units) below what was measured; the range from low to high includes it.
By their numbers in this assay, from the lowest: compounds 1 and 2 (each within the scatter of the next); then compound 3.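

In this assay, the aromatic carbon that carries these groups proves not to be indifferent to the group placed there. 2-Phenylethenyl in place of furan-3-yl gives a 4.0-fold higher number from compound 2 to compound 3 (0.60 log units; beyond the scatter), and in place of hex-1-yn-1-yl it gives a 5.0-fold higher number from compound 1 to compound 3 (0.70 log units; beyond the scatter), whereas the earlier exchange of hex-1-yn-1-yl for furan-3-yl, a 1.3-fold higher number from compound 1 to compound 2 (0.10 log units; within the scatter), showed no change beyond the scatter. Both new steps are modest, and nothing measured here accounts for them.

The compounds shown leave open whether a phenyl group attached directly to that carbon, or a saturated 2-phenylethyl chain, would stay with compound 1 and compound 2 or fall with compound 3. Also open, going by these compounds, is how a small amine or a carboxylic acid at this position would read in this assay.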